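Chloro for fluoro on the benzyloxy ring of compound 3

The compounds below may be only part of what the source reports. "The series", "measured", "known", "first", "only" and "open" are said of these compounds alone.

Three members of this series have been measured in a functional assay on HeLa cells (Homo sapiens) for antiproliferative activity, read by MTT assay, with a stated time of 48 h, in the presence of a further agent that is not named here; on this read-out higher numbers stand for weaker inhibition of growth and lower numbers for stronger inhibition of growth. Compound 1 `Cc1ccc(-c2nn(-c3ccccc3)cc2C(=O)NOCc2ccccc2Cl)cc1` gives 4680 nM. Compound 2 `O=C(NOCc1ccccc1)c1cn(-c2ccccc2)nc1-c1ccc(Cl)cc1` gives 8350 nM. Compound 3 `O=C(NOCc1ccccc1F)c1cn(-c2ccccc2)nc1-c1ccc(Cl)cc1` gives 4170 nM, the lowest of the three numbers; the gap to compound 1 and the gap to compound 2 both lie within the scatter, so no order among the three can be claimed.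

One change within the measured set is a single substitution: a 2.0-fold lower number from compound 2 to compound 3 (0.30 log units; within the scatter), a change within the scatter.

Compound 4 `O=C(NOCc1ccccc1Cl)c1cn(-c2ccccc2)nc1-c1ccc(Cl)cc1` differs from compound 3 in one place: chloro in place of fluoro on an aromatic carbon, that is, the (2-fluorobenzyl)oxy group becomes a (2-chlorobenzyl)oxy group, on an aromatic carbon ortho to a large group. Within the data shown here, no measured pair shows chloro replacing fluoro directly. Among the measured compounds shown here, the only step that bears on this position, the one from compound 2 to compound 3, stayed within the scatter, and compound 1, which also carries a (2-chlorobenzyl)oxy group, sits within the scatter of compound 3 in this assay. Compound 4 is therefore expected to stay close to compound 3, with a step of a 1.2-fold lower number from compound 3 to compound 4 (0.06 log units; within the scatter) that is not expected to exceed the scatter. The estimate for compound 4 in this assay is 3600 nM, with a range from 1500 nM to 8500 nM.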

Compound 4, concentration for 50% growth inhibition: 8850 nM
For compound 4 the middle estimate is 2.5-fold (0.39 log units) below the measured one, outside the stated range (above it).
By their numbers in this assay, from the lowest: compounds 3, 1, 2 and 4 (each within the scatter of the next, the first and the last beyond it).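

In this assay, the swap of chloro for fluoro on the aromatic carbon gives a 2.1-fold higher number from compound 3 to compound 4 (0.33 log units; beyond the scatter) as a modest step, the first at this position to pass the scatter, so the two halogens can be told apart here. Among these compounds, neither halogen stands apart from hydrogen, however: fluoro gives a 2.0-fold lower number from compound 2 to compound 3 (0.30 log units; within the scatter) and chloro gives a 1.1-fold higher number from compound 2 to compound 4 (0.03 log units; within the scatter) as the matching step, which means that only the contrast between fluoro and chloro registers at this place, and no step from the unsubstituted benzyloxy compound does. With the (2-chlorobenzyl)oxy group held constant, chloro in place of methyl on the other aromatic ring gives a 1.9-fold higher number from compound 1 to compound 4 (0.28 log units; within the scatter) as its step, so that exchange does not register in this read-out either.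

The compounds shown leave open whether a bromo or methoxy group at this place would follow fluoro or chloro, and whether the gap between the two halogens would recur on the core of compound 1, which carries methyl. Nothing available explains why fluoro and chloro part here.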